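A few compounds are considered here, and "the series" means these few. Any claim that something is new, unique, unknown or untested is made for them only; others in the source may bear on it.

Compound 2 `O=C(CN1CCN(c2ncccn2)CC1)Nc1nc2ccccc2[nH]1` gives 20.4% in a functional assay, read by spectrophotometry, with a stated time of 30 min, tested at 25 ug/mL; a lower number here means a weaker effect, a higher number a stronger effect of the compound at the concentration tested. Its only measured companion, compound 1 `O=C(CN1CCN(c2ccccc2F)CC1)Nc1nc2ccccc2[nH]1`, gives 18.8% in this assay. The step of a number 1.6 percentage points higher from compound 1 to compound 2 (within the scatter) shows that exchanging the aromatic group on the amine nitrogen in the ring left the read-out essentially where it was; of the two numbers, compound 2 nominally holds the upper one, yet the gap to compound 1 is covered by the scatter. Compound 3 `O=C(CN1CCN(c2ccc([N+](=O)[O-])cc2)CC1)Nc1nc2ccccc2[nH]1` differs from compound 2 by 4-nitrophenyl in place of pyrimidin-2-yl on an amine nitrogen in a ring. Going by the values given here, the one measured step concerns the same place and the same kind of exchange, one aromatic ring for another, and it was small. Among the compounds with values here, no measured step involves a 4-nitrophenyl group, so nothing more specific is known. A step of similar small size is expected, in either direction or none beyond the scatter, and the estimate a number 0.4 percentage points lower from compound 2 to compound 3 (within the scatter) reflects this. Compound 3 is expected to give 20%, within a likely range from 8% to 34%.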

Compound 3, a percentage reported as activity, at one concentration (the size of the read-out at that concentration, not a potency): 33.9%
Estimate against measurement, compound 3: 13.9 percentage points below; the range from low to high includes it.
By their numbers in this assay, from the lowest: compounds 1 and 2 (each within the scatter of the next); then compound 3.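

In this assay, placing 4-nitrophenyl on this amine nitrogen gives a number 13.5 percentage points higher from compound 2 to compound 3 (beyond the scatter) when it replaces pyrimidin-2-yl and a number 15.1 percentage points higher from compound 1 to compound 3 (beyond the scatter) when it replaces 2-fluorophenyl, so the read-out at this position does respond to the choice of aromatic group. Exchanging one aromatic ring for another here therefore does not always leave the number in place, as the first pair alone might have suggested. Nothing available explains why this group stands apart from the other two.

Whether the nitro group or its phenyl ring accounts for the higher number stays open, and plain phenyl or 4-aminophenyl would help separate the two. Also open, on these data alone, is how a group without an aromatic ring, such as a simple alkyl chain, would behave at this nitrogen.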